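The compounds below may be only part of what the source reports. "The series", "measured", "known", "first", "only" and "open" are said of these compounds alone.

Measured so far:
- compound 1 `COc1ccc(NC(=O)NS(=O)(=O)N2CCC(CCNC(=O)c3cc(Cl)ccc3OC)CC2)cc1`: 27%
- compound 2 `O=C(NC1CCCCC1)NS(=O)(=O)N1CCC(CCNC(=O)C(F)(F)F)CC1`: 13%
- compound 3 `O=C(NC[C@@H]1C[C@@H]2C=C[C@@H]1C2)NS(=O)(=O)N1CCC(CCNC(=O)C(F)(F)F)CC1`: 22%

The read-out here is a functional assay on the whole organism (blood) with Rattus norvegicus as the target, with stated times of 24 h and 1 h, at a dose of 5 mg/kg by the intraperitoneal route; on this read-out higher numbers stand for a stronger effect at the one dose given and lower numbers for a weaker effect. Among the three measured compounds, compound 2 stands at the lowest number. Compound 3 sits close to it, the step of a number 9 percentage points higher from compound 2 to compound 3 (within the scatter) being within the scatter, so the two cannot be ordered. Compound 1 lies further off; its value is beyond the scatter from compound 2, though no single change separates these two, since they differ at more than one place.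

Compound 4 `O=C(NC1CCCCC1)NS(=O)(=O)N1CCC(CCNC(=O)c2ccnc3ccccc23)CC1` has not yet been measured. It arises from compound 2 by one change: quinolin-4-yl in place of trifluoromethyl on a carbonyl carbon. Among the compounds with values here, only one measured step exists, the one from compound 2 to compound 3, and it concerns the group on the amide-type nitrogen, not the carbonyl carbon altered here, so it does not bear directly on this change. Within the data shown here, no measured step therefore speaks to the change itself. Among the measured compounds shown here, the values of compound 1 and compound 2 show only that the higher number belongs to the compound carrying an aromatic ring on that carbonyl, but those two differ elsewhere too.

Given this, the step from compound 2 to compound 4 is expected to be small and uncertain, a number 8 percentage points higher from compound 2 to compound 4 (within the scatter), leaning slightly upward. Compound 4 is estimated at 21%, in a range from 8% to 38%.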

Compound 4, a percentage reported as activity, at one dose (the size of the read-out at that dose, not a potency): 16%
Beside the measured number, compound 4's estimate is 5 percentage points above it; the range from low to high includes it.
By their numbers in this assay, from the lowest: compounds 2, 4, 3 and 1 (each within the scatter of the next, the first and the last beyond it).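

Within the data shown here, replacing trifluoromethyl with quinolin-4-yl on a carbonyl carbon gives the first direct reading for this position in this assay, and the result is a number 3 percentage points higher from compound 2 to compound 4 (within the scatter). Trifluoromethyl, which has no ring, gives way to quinolin-4-yl, which has two six-membered aromatic rings and a hydrogen-bond acceptor, yet this large change in the group produces no difference that can be told from the scatter at this one dose. No evidence is available that would explain this result.

What the compounds shown leave open is whether any other group on this carbonyl carbon, such as a simple methyl, a plain phenyl ring, a longer chain ending in an amine or one ending in a carboxylic acid, would move the number beyond the scatter. As far as these compounds go, it also remains open whether quinolin-4-yl would behave the same way with a different group on the amide-type nitrogen, such as the two-ring carbon group of compound 3.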